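From 4-methylphenyl to 2-nitrophenyl on the sulfonyl sulfur

This account rests on a few compounds, and the source may have more. Where it says the series, first, only, none or still open, it means among the compounds named here.

Measured in a functional assay on RKOp27 cells (Homo sapiens) for cytotoxicity, read by MTT assay, with a stated time of 3 days; on this read-out higher numbers stand for weaker inhibition and lower numbers for stronger inhibition:
Compound 1 `CN1CCN(c2nc(SCc3nc4ccccc4[nH]3)nc(-c3ccccc3)c2C#N)CC1` gives 5.4 nM
Compound 2 `N#Cc1c(-c2ccccc2)nc(SCc2nc3ccccc3[nH]2)nc1N1CCN(S(=O)(=O)c2ccccc2)CC1` gives 7.35 nM
Compound 3 `Cc1ccc(S(=O)(=O)N2CCN(c3nc(SCc4nc5ccccc5[nH]4)nc(-c4ccccc4)c3C#N)CC2)cc1` gives 2.5 nM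

Compound 3 has the lowest of the three numbers, at 2.5 nM. Compound 4 `N#Cc1c(-c2ccccc2)nc(SCc2nc3ccccc3[nH]2)nc1N1CCN(S(=O)(=O)c2ccccc2[N+](=O)[O-])CC1` has not yet been measured. It carries 2-nitrophenyl in place of 4-methylphenyl on a sulfonyl sulfur. Among the measured compounds shown here, no measured compound carries 2-nitrophenyl, so the evidence is indirect. The closest guide is the methyl in place of hydrogen on an aromatic carbon, which gave a 2.9-fold lower number from compound 2 to compound 3 (0.47 log units; beyond the scatter). Compound 4 lacks that methyl. The other sulfonyl comparison, a 1.4-fold higher number from compound 1 to compound 2 (0.13 log units; within the scatter), stayed small. A modest rise is therefore expected in this assay, with an estimated 2.4-fold higher number from compound 3 to compound 4 (0.38 log units; beyond the scatter). Compound 4 is estimated at 6 nM, with an expected range of 2 nM to 18 nM.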

Compound 4, half-maximal inhibitory concentration: 5.6 nM
For compound 4 the middle estimate is 1.1-fold (0.03 log units) above the measured one; the range from low to high includes it.
By their numbers in this assay, from the lowest: compound 3; then compounds 1, 4 and 2 (each within the scatter of the next).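

In this assay, a substituent on the phenyl ring other than methyl now has a reading, and a 2.2-fold higher number from compound 3 to compound 4 (0.35 log units; beyond the scatter) shows that 2-nitrophenyl does not reproduce what 4-methylphenyl gives on this sulfonyl sulfur. Nitro in place of hydrogen makes no readable difference, with a 1.3-fold lower number from compound 2 to compound 4 (0.12 log units; within the scatter), and neither does the whole (2-nitrophenyl)sulfonyl group in place of methyl on the ring nitrogen, with a 1.0-fold higher number from compound 1 to compound 4 (0.02 log units; within the scatter). Nothing available explains these results. Open, on these data alone, is whether 2-methylphenyl would match 4-methylphenyl, and how 4-nitrophenyl or 4-methoxyphenyl would read here.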